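Ether in place of dimethylamino on the shared core

The source may report more compounds than this note shows. Statements on the series, on what has been measured and on what is new or still open speak of the compounds shown alone.

Measured in a functional assay on CHO cells for antagonist activity at metabotropic glutamate receptor 1 (Rattus norvegicus), with a stated time of 5 min; a lower number here means a stronger inhibitor, a higher number a weaker inhibitor:
compound 1 `CN(C)c1cc2c(NC3CCCCC3)ncnc2cn1` gives 199 nM
compound 2 `CCCC(C)Nc1ncnc2cnc(N(C)C)cc12` gives 858 nM
compound 3 `OCCNc1cc2c(NCCO)ncnc2cn1` gives 6150 nM

Compound 1 has the lowest number of the three. Its nearest neighbour is compound 2, reached by one change on the nitrogen on the aromatic ring: a 4.3-fold higher number from compound 1 to compound 2 (0.63 log units; beyond the scatter). Compound 3 stands furthest away; it differs from compound 1 in two places at once, so its value can only be set beside that of compound 1, not read as a single step.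

Compound 4 `COCCOc1cc2c(NC3CCCCC3)ncnc2cn1` is the next candidate. It differs from compound 1 by 2-methoxyethoxy in place of dimethylamino on an aromatic carbon. Going by the values given here, the one measured step, from compound 1 to compound 2, alters a different part of the molecule and so does not bear on this exchange. Compound 3 carries a different group at the same place as the dimethylamino, but its second change prevents any separation of the two effects. Among the compounds with values here, there is therefore no measured step that speaks to the 2-methoxyethoxy group directly.

With that gap in mind, a modest weakening is expected rather than a gain: the estimate for compound 4 in this assay is 500 nM, with a range from 150 nM to 2000 nM, which corresponds to an expected step of a 2.5-fold higher number from compound 1 to compound 4 (0.40 log units; beyond the scatter).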

Compound 4, inhibition constant: 101 nM
Estimate against measurement, compound 4: 5.0-fold (0.69 log units) above, outside the stated range (below it).
By their numbers in this assay, from the lowest: compounds 4 and 1 (each within the scatter of the next); then compound 2; then compound 3.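

In this assay, the exchange of dimethylamino for 2-methoxyethoxy on the aromatic carbon next to the ring nitrogen gives a step that stays small (a 2.0-fold lower number from compound 1 to compound 4 (0.29 log units; within the scatter)), so compound 1 and compound 4 cannot be told apart in this read-out. With the cyclohexyl amine held constant, this position therefore accepts a change from a group of 3 heavy atoms with a nitrogen to an open chain of 5 heavy atoms with two oxygens, and the nitrogen of the dimethylamino group is not needed to keep the value in this range, a point that compound 3, with its second change, could not show. No measured information on the reason for this equivalence is available.

Still open, as far as these compounds go, is how far this holds for other groups at this position, such as a methoxy group, a morpholine ring, a primary amine, a carboxylic acid or a longer ether chain. Also open is whether 2-methoxyethoxy gives a comparable result when 1-methylbutyl replaces cyclohexyl on the nitrogen, as that pairing is not among the compounds shown.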